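A few compounds are considered here, and "the series" means these few. Any claim that something is new, unique, unknown or untested is made for them only; others in the source may bear on it.

Three compounds have numbers in a functional assay on MDA-MB-435 cells (Homo sapiens) for inhibition; a lower number here means a stronger inhibitor, a higher number a weaker inhibitor. Among the compounds with values here, compound 1 `O=C(/C=C/c1ccc(F)c(Br)c1)c1ccc(B(O)O)cc1` gives 8800 nM and compound 3 `O=C(/C=C/c1ccc(F)c(Cl)c1)c1ccc(B(O)O)cc1` gives 16000 nM; the one measured step, a 1.8-fold higher number from compound 1 to compound 3 (0.26 log units; within the scatter), lies within the scatter. Compound 2 `O=C(/C=C/c1ccccc1)c1ccc[nH]1` gives 15000 nM, a number within the scatter of both others, so none of the three stands apart. Compound 4 `O=C(/C=C/c1ccc(B(O)O)cc1)c1ccc[nH]1` is compound 2 with a group of 3 heavy atoms (1 boron, 2 oxygen; no ring) in place of a hydrogen atom, on an aromatic carbon. Within the data shown here, no measured step covers this change: the only step on record swaps chloro for bromo, and no measured pair differs by the presence of a group of 3 heavy atoms (1 boron, 2 oxygen). With nothing to rest on, no step beyond the scatter is expected from compound 2 to compound 4, a 1.2-fold lower number from compound 2 to compound 4 (0.06 log units; within the scatter). Compound 4 is estimated at 13000 nM, with a range of 4000 nM to 40000 nM.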

Compound 4, half-maximal inhibitory concentration: 15000 nM
Compound 4: middle estimate off by 1.2-fold (0.06 log units), on the low side, within the range that was stated.
By their numbers in this assay, from the lowest: compounds 1, 2, 4 and 3 (each within the scatter of the next).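

In this assay the swap at this position reads no change at the digits printed from compound 2 to compound 4 (within the scatter), so a group of 3 heavy atoms (1 boron, 2 oxygen) in place of a hydrogen atom, on an aromatic carbon of a six-membered aromatic ring of carbon only, gives no step beyond the scatter on this core. Within the data shown here, the only earlier step concerned chloro and bromo, so this is the first reading for this position and this change. Nothing measured here offers an explanation for this result.

Going by these compounds, whether an amine or a carboxylic acid at this position would give a step beyond the scatter remains open. Also open, on these data alone, is whether the same change gives the same result on other cores.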